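The compounds below may be only part of what the source reports. "The series", "measured", "known", "first", "only" and "open" are said of these compounds alone.

Going by the values given here, only two compounds have been measured so far. In a functional assay on A-375 cells (Homo sapiens) for cytotoxicity, read by CCK-8 assay, with a stated time of 24 h (a lower number here means a stronger inhibitor, a higher number a weaker inhibitor), compound 1 `COc1ccccc1Oc1c(N)nc(-c2cccc(C)c2)nc1Cl` gives 65300 nM. Compound 2 `COc1ccccc1Oc1c(N)nc(-c2cccc(Cl)c2)nc1Cl` gives 38300 nM, which lies within the usual scatter of the first number, so neither compound can be ranked ahead of the other. Compound 3 `COc1ccccc1Oc1c(N)nc(-c2ccc(Br)cc2)nc1Cl` carries 4-bromophenyl in place of 3-chlorophenyl on an aromatic carbon. Among the compounds with values here, the only measured step on this same aromatic ring is a 1.7-fold lower number from compound 1 to compound 2 (0.23 log units; within the scatter), which put chloro in place of methyl. Within the data shown here, that step stayed small, but no measured compound carries the 4-bromophenyl group, so the guidance is indirect and the range must stay wide. The expected change in this assay is a 1.0-fold higher number from compound 2 to compound 3 (0.02 log units; within the scatter), which means no expected shift beyond the scatter. For compound 3 the estimated value is 40000 nM, with an expected range from 15000 nM to 100000 nM.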

Compound 3, half-maximal inhibitory concentration: 63 nM
Estimate against measurement, compound 3: 630-fold (2.80 log units) above; measured number below the stated range.
By their numbers in this assay, from the lowest: compound 3; then compounds 2 and 1 (each within the scatter of the next).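

In this assay, the group on the ring carbon between the two ring nitrogen atoms turns out to matter far more than the earlier pair suggested: 4-bromophenyl in place of 3-chlorophenyl gives a 610-fold lower number from compound 2 to compound 3 (2.78 log units; beyond the scatter), and 4-bromophenyl in place of 3-methylphenyl gives a 1000-fold lower number from compound 1 to compound 3 (3.02 log units; beyond the scatter). The groups that leave and enter match in heavy-atom count and in having no hydrogen-bond donors or acceptors, so those counts do not separate them. Nothing measured here explains the size of this jump.

Compound 3 changes both the halogen and its place on the phenyl ring, so the compounds shown cannot say which change matters; 4-chlorophenyl and 3-bromophenyl would separate the two. From the compounds shown here alone, whether 4-methylphenyl or 4-methoxyphenyl would keep such a low number also stays open.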